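Chloro for methyl on the fused ring

A few compounds are considered here, and "the series" means these few. Any claim that something is new, unique, unknown or untested is made for them only; others in the source may bear on it.

In an assay on isolated protein for inhibition of tyrosine-protein kinase receptor TYRO3 (Homo sapiens), read by LC-MS, with stated times of 30 min and 180 min (a lower number here means a stronger inhibitor, a higher number a weaker inhibitor), compound 2 `CNC(=O)c1sc(N2CC3CC2(CNC(=O)c2c[nH]c4ncc(C)cc24)C3)nc1C(F)(F)F` gives 1000 nM. For the measured compounds named here, the only other number comes from compound 1 `CNC(=O)c1sc(N2CC3CC2(CNC(=O)c2c[nH]c4ncccc24)C3)nc1C(F)(F)F`, which gives 2000 nM; the step of a 2.0-fold lower number from compound 1 to compound 2 (0.30 log units; within the scatter) lies within the scatter, so the two stand together. Compound 3 `CNC(=O)c1sc(N2CC3CC2(CNC(=O)c2c[nH]c4ncc(Cl)cc24)C3)nc1C(F)(F)F` carries the change (chloro in place of methyl on an aromatic carbon). Going by the values given here, the one measured step at this position, methyl in place of hydrogen from compound 1 to compound 2, stayed within the scatter, and no measured step puts chloro in place of methyl. The step of no change at the digits printed from compound 2 to compound 3 (within the scatter) is therefore expected to be small. Compound 3 is estimated at 1000 nM, from 400 nM to 2500 nM.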

Compound 3, half-maximal inhibitory concentration: 631 nM
Estimate against measurement, compound 3: 1.6-fold (0.20 log units) above, within the range that was stated.
By their numbers in this assay, from the lowest: compounds 3, 2 and 1 (each within the scatter of the next, the first and the last beyond it).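

Chloro where hydrogen stood gives a 3.2-fold lower number from compound 1 to compound 3 (0.50 log units; beyond the scatter) in this assay and is the only step at this position that lies beyond the scatter, while chloro in place of methyl gives a 1.6-fold lower number from compound 2 to compound 3 (0.20 log units; within the scatter) and leaves compound 2 and compound 3 standing together. So at this position only chloro has yet separated from hydrogen, and methyl has not. No measurement given here explains these numbers.

The compounds shown leave open what a methoxy group, a nitrile or an amine would give at this position. They also leave open whether bromo or fluoro would stand with chloro.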